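From Compound 1 to Compound 3: Chloro in Place of Fluoro

A few compounds are considered here, and "the series" means these few. Any claim that something is new, unique, unknown or untested is made for them only; others in the source may bear on it.

Compound 1 `Cn1cnc(C(=O)NNC(=O)COc2c(F)cc(C(=O)c3ccc(F)cc3)cc2Cl)c1` was examined in a functional assay on A549 cells (Homo sapiens) for cytotoxicity, read by trypan blue exclusion, with a stated time of 48 h (a higher number here means a weaker inhibitor, a lower number a stronger inhibitor), where compound 1 gives 39600 nM. Within the data shown here, that is the higher of the two numbers recorded so far, yet the only other measured compound, compound 2 `Cn1cnc(C(=O)NNC(=O)COc2ccc(C(=O)c3ccccc3)cc2)c1`, which in this assay gives 29600 nM, lies within the scatter of compound 1, so the two cannot be told apart. Compound 3 `Cn1cnc(C(=O)NNC(=O)COc2c(F)cc(C(=O)c3ccc(Cl)cc3)cc2Cl)c1` has not yet been measured. It differs from compound 1 in one place: chloro in place of fluoro on an aromatic carbon. Among the measured compounds shown here, no measured pair in this set shows what such an exchange does, so the data fix neither the size nor the direction of the step. The sensible expectation is therefore a change no larger than the scatter, in either direction. Compound 3 is accordingly expected to give about 35000 nM, with a likely range from 12000 nM to 100000 nM. The step of a 1.1-fold lower number from compound 1 to compound 3 (0.05 log units; within the scatter) is thus estimated to be slight.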

Compound 3, half-maximal inhibitory concentration: 47300 nM
Compound 3: the middle estimate sits 1.4-fold (0.13 log units) below what was measured; measured number inside the range.
By their numbers in this assay, from the lowest: compounds 2, 1 and 3 (each within the scatter of the next).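

Among these compounds, replacing 4-fluorophenyl with 4-chlorophenyl provides the first comparison in this set between compounds that differ in only one place. In this assay the step reads a 1.2-fold higher number from compound 1 to compound 3 (0.08 log units; within the scatter) and leaves compound 1 and compound 3 indistinguishable. On this aromatic carbon, para to a large group, fluoro and chloro therefore cannot be separated by this read-out, although a single pair says nothing about other substituents there, and no other measurement bears on why the two compounds match.

As far as these compounds go, whether an amine, a carboxylic acid or a methoxy group at this place would give a number beyond the scatter remains open. Among the compounds shown here, also open is what the remaining fluoro and chloro on the shared core contribute, as no single-place step isolates either of them.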